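The source may hold more compounds than are shown below. What is called first, only, known or untested is meant among the compounds shown, and "the series" means these compounds.

Of the compounds shown here, three of a shared core have been measured in an assay for inhibition of cytochrome P450 1A1 (Homo sapiens), read by fluorescence, using microsomes, with a stated time of 10 min; on this read-out higher numbers stand for weaker inhibition and lower numbers for stronger inhibition. Compound 1, `CCc1ccc(/C=C/C(=O)c2ccc[nH]2)o1`, is reported only as a limit of the assay, > 20000 nM. Compound 2, `COc1ccccc1/C=C/C(=O)c1ccc[nH]1`, gives a number, 900 nM. Compound 3, `O=C(/C=C/C=C/c1ccccc1)c1ccc[nH]1`, is likewise reported only as a limit, > 20000 nM. On the numbers shown, then, compound 3 stands at the weak end: its value is a limit, and it shares that position with one further value, a point summed up by the limit of > 20000 nM in this assay, at which 2 of the 3 values shown sit.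

Compound 4, `COc1ccc(/C=C/C=C/C(=O)c2ccc[nH]2)cc1`, has not yet been measured. It differs from compound 3 in one place: methoxy in place of hydrogen on an aromatic carbon. Going by the values given here, no step between measured compounds is on record, so there is nothing from which the size of this change can be read off directly. Compound 2, which also carries a methoxy, gives a number rather than a limit, but compound 2 differs from compound 3 in more than the methoxy, so that comparison does not isolate the change. The expectation is therefore a modest gain, an at least 1.6-fold lower number from compound 3 to compound 4 (0.22 log units; that floor lies within the scatter), with a real chance that the step stays within the scatter. Compound 4 is expected to give 12000 nM, within a range from 3000 nM to 40000 nM.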

Compound 4, half-maximal inhibitory concentration: > 20000 nM
Compound 4 ended at the assay's limit; the forecaster's own chance of this, stated with the estimate: 45%; middle value at least 1.6-fold (0.22 log units) away from the limit.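

No size can be read for the change from compound 3 to compound 4, methoxy in place of hydrogen on an aromatic carbon, because both stand at a limit of the assay rather than at a number: the limit of > 20000 nM in this assay, at which 3 of the 4 values shown sit. The compounds shown leave open whether this methoxy changes inhibition at all: any difference between the two would lie out of sight beyond the limit.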